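The compounds below may be only part of what the source reports. "The series", "measured", "known", "first", "only" and "open" are said of these compounds alone.

Three compounds have been measured in a physicochemical assay for lipophilicity, in phosphate buffer, measured as octanol-water partition; on this read-out higher numbers stand for higher lipophilicity and lower numbers for lower lipophilicity:

compound 1, `O=C(NC(=S)Nc1ccccc1)Nc1ccc2c(c1)C(=O)C(=O)N2Cc1ccccc1Cl`, 3.18
compound 2, `O=C(NC(=S)Nc1ccccc1Cl)Nc1ccc2c(c1)C(=O)C(=O)N2Cc1ccccc1Cl`, 3.98
compound 3, `COc1ccccc1NC(=S)NC(=O)Nc1ccc2c(c1)C(=O)C(=O)N2Cc1ccccc1Cl`, 3.18

Going by the values given here, compound 3 stands level with compound 1 at the digits printed, the two together being the lowest of the three numbers; its only step beyond the scatter is that to compound 2, a number 0.80 log units lower from compound 2 to compound 3 (beyond the scatter) read backwards. The move to compound 4, `COc1ccc(NC(=S)NC(=O)Nc2ccc3c(c2)C(=O)C(=O)N3Cc2ccccc2Cl)cc1`, is 4-methoxyphenyl in place of 2-methoxyphenyl on an amide-type nitrogen. Among the compounds with values here, no measured step rearranges a methoxy group on that ring, so none bears on it directly. The nearest guidance is no change at the digits printed from compound 1 to compound 3 (within the scatter), which shows the methoxy group at its present place adding nothing to the parent, and a number 0.80 log units higher from compound 1 to compound 2 (beyond the scatter), which shows a chloro group at the same place adding a modest amount. Shifting the methoxy group is therefore expected to give at most a small step in this assay, a number 0.08 log units lower from compound 3 to compound 4 (within the scatter), within the scatter. Compound 4 is expected at 3.1, between 2.7 and 3.5.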

Compound 4, partition coefficient: 3.24
The estimate for compound 4 lay 0.14 log units below the measured number, and the stated range covers the measured number.
By their numbers in this assay, from the lowest: compounds 1, 3 and 4 (each within the scatter of the next); then compound 2.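

In this assay, going by these compounds alone, exchanging 2-methoxyphenyl for 4-methoxyphenyl on the amide-type nitrogen gives a step too small to separate the two placements (a number 0.06 log units higher from compound 3 to compound 4 (within the scatter)), which no earlier pair could show, since none rearranged the methoxy group on that ring. The same holds against the compound with no methoxy group at all (a number 0.06 log units higher from compound 1 to compound 4 (within the scatter)), whereas the 2-chlorophenyl compound remains apart (a number 0.74 log units lower from compound 2 to compound 4 (beyond the scatter)), so among these four compounds only that group separates from the rest. Nothing at hand offers an explanation for this.

Going by these compounds, it remains open whether an amine or a carboxylic acid on this ring would shift the number beyond the scatter. Equally open, on these data alone, is whether a longer chain, such as ethoxy or propoxy in place of methoxy, would stay level with these compounds.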